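A few compounds are considered here, and "the series" means these few. Any claim that something is new, unique, unknown or untested is made for them only; others in the source may bear on it.

Measured so far in an assay on HEK293 cells for positive allosteric modulation of metabotropic glutamate receptor 2 (Rattus norvegicus), read by thallium flux, with a stated time of 2.5 min; on this read-out lower numbers stand for smaller maximal responses and higher numbers for larger maximal responses:
compound 1, `COC(=O)c1ccc(OCCCCOc2ccc(C(=O)CC3CCCC3)c(O)c2C)cc1`: 12.2%
compound 2, `Cc1c(OCCCCOc2ccccc2C(=O)O)ccc(C(=O)CC2CCCC2)c1O`: 98.8%

Compound 2 stands highest of the two numbers in this assay; its nearest neighbour is compound 1, and the step of a number 86.6 percentage points higher from compound 1 to compound 2 (beyond the scatter) is large. Compound 3, `Cc1c(OCCCCOc2cccc(C(=O)O)c2)ccc(C(=O)CC2CCCC2)c1O`, differs from compound 2 by 3-carboxyphenyl in place of 2-carboxyphenyl on an oxygen on a saturated carbon. Among the compounds with values here, only the step from compound 1 to compound 2 touches this position, and it changed both the group and its attachment, so it bears on the move only loosely. A downward step of middling size, a number 43.8 percentage points lower from compound 2 to compound 3 (beyond the scatter), is expected, with wide uncertainty. Compound 3 is estimated at 55%, range 15% to 95%.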

Compound 3, largest response reached (reported as percent of maximum), in percent of the reference or control that the assay uses: 80.6%
For compound 3 the middle estimate is 25.6 percentage points below the measured one, and the stated range covers the measured number.
By their numbers in this assay, from the lowest: compound 1; then compound 3; then compound 2.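

In this assay the change to 3-carboxyphenyl on an oxygen on a saturated carbon gives a number 18.2 percentage points lower from compound 2 to compound 3 (beyond the scatter) and still leaves a large response, so a high reading does not rest on 2-carboxyphenyl alone. The 3-carboxyphenyl group also gives a number 68.4 percentage points higher from compound 1 to compound 3 (beyond the scatter) against 4-(methoxycarbonyl)phenyl, though group and attachment change together in that step. Nothing at hand accounts for the gap between the two carboxyphenyl compounds.

Open, from the compounds shown here alone, is how 4-carboxyphenyl would read, which would separate attachment from the change between methyl ester and carboxylic acid. Also open, going by these compounds, is how 3-(methoxycarbonyl)phenyl would compare with its carboxylic acid counterpart in compound 3.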